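The source may hold more compounds than are shown below. What is called first, only, known or untested is meant among the compounds shown, and "the series" means these compounds.

Working notes on the series in a functional assay on CHO-K1 cells for antagonist activity at adenosine receptor A1 (Homo sapiens), read by a beta-galactosidase reporter and cAMP accumulation, with stated times of 15 min and 6 h; a higher number here means a weaker inhibitor, a lower number a stronger inhibitor.

Three compounds share the core of compound 1 `Cc1csc(-c2nc(N)c3cc(Cc4ccccc4)sc3n2)n1` and differ only in the group carried on the five-membered sulfur ring. In this assay compound 1 gives 1490 nM. Compound 2 `Cc1csc(-c2nc(N)c3cc(Cc4ccccc4Cl)sc3n2)n1` gives 49.6 nM. Compound 3 `Cc1csc(-c2nc(N)c3cc(C(C)c4ccccc4)sc3n2)n1` gives 1420 nM. Compound 3 therefore sits second highest of the three numbers; its nearest neighbour is compound 1, with a 1.0-fold lower number from compound 1 to compound 3 (0.02 log units; within the scatter), while the furthest step is a 29-fold higher number from compound 2 to compound 3 (1.46 log units; beyond the scatter).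

The next compound, compound 4 `C=C(c1ccccc1)c1cc2c(N)nc(-c3nc(C)cs3)nc2s1`, differs from compound 3 by 1-phenylethenyl in place of 1-phenylethyl on an aromatic carbon. For the measured compounds named here, of the measured steps, the one closest in kind is the one from compound 1 to compound 3, where a methyl entered the saturated chain carbon bound to two aromatic carbons and gave a 1.0-fold lower number from compound 1 to compound 3 (0.02 log units; within the scatter). The large steps of a 30-fold lower number from compound 1 to compound 2 (1.48 log units; beyond the scatter) and a 29-fold higher number from compound 2 to compound 3 (1.46 log units; beyond the scatter) both turn on the chloro on the aromatic carbon, which is untouched here. Going by the values given here, no measured step changes the saturation of that chain carbon, so nothing in the data points to a shift beyond the scatter.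

Compound 4 is therefore expected to give about 1400 nM, within roughly 450 nM to 4500 nM, which amounts to an expected step of a 1.0-fold lower number from compound 3 to compound 4 (0.01 log units; within the scatter).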

Compound 4, inhibition constant: > 594 nM
Compound 4: only a limit was reported (the forecaster's own chance of this, stated with the estimate: 5%); the middle value does not contradict the limit.
By their numbers in this assay, from the lowest: compound 2; then compounds 3 and 1 (each within the scatter of the next).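

In this assay compound 4 carries a limit of the assay and not a number: the limit of > 594 nM in this assay, at which 1 of the 4 values shown sits.

Its steps from compound 3 and from compound 1 cannot be read, which leaves the exchange of 1-phenylethyl for 1-phenylethenyl, on this aromatic carbon next to the ring sulfur, without a size. For the compounds shown here, the one readable step is an at least 11-fold higher number from compound 2 to compound 4 (1.07 log units; beyond the scatter), with 1-phenylethenyl in place of 2-chlorobenzyl, and it adds a third group carrying an unsubstituted phenyl ring that stands beyond the scatter from compound 2, which keeps the lowest number of the four.

From the compounds shown here alone, whether the double bond outside the aromatic rings changes the number at all relative to 1-phenylethyl remains open, and a numerical reading for compound 4 would be needed to settle it. Also open, going by these compounds, is what a hydroxyl or a carbonyl at the same chain carbon would give, and whether a chloro on the phenyl ring of 1-phenylethyl or 1-phenylethenyl would bring a step of the kind seen in a 30-fold lower number from compound 1 to compound 2 (1.48 log units; beyond the scatter).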